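This account rests on a few compounds, and the source may have more. Where it says the series, first, only, none or still open, it means among the compounds named here.

Working notes on the amine end of the series. In a functional assay on A2780 cells (Homo sapiens) for antiproliferative activity, read by MTT assay, with a stated time of 48 h (on this read-out higher numbers stand for weaker inhibition and lower numbers for stronger inhibition), compound 1 (`C=C(c1ccc(OC)cc1NC(=O)CN)c1ccc(OC)c2c1OC(C)(C)C=C2`) gives 80 nM and compound 2 (`C=C(c1ccc(OC)cc1NC(=O)CNC)c1ccc(OC)c2c1OC(C)(C)C=C2`) gives 210 nM. Compound 2 therefore holds the higher of the two numbers, the weaker inhibition of the pair. Compound 3 (`C=C(c1ccc(OC)cc1NC(=O)CN(C)C)c1ccc(OC)c2c1OC(C)(C)C=C2`) differs from compound 2 in one place: methyl in place of hydrogen on an amine nitrogen. This is methylamino to dimethylamino, with methyl in place of hydrogen on an amine nitrogen. One measured step is of the same kind: a 2.6-fold higher number from compound 1 to compound 2 (0.42 log units; beyond the scatter), modest and beyond the scatter. Within the data shown here, a single step sets no trend, and no dimethylamino compound has a measured value yet. A modest step toward a higher number is nevertheless expected in this assay. The estimated step is a 2.1-fold higher number from compound 2 to compound 3 (0.33 log units; beyond the scatter). Compound 3 is estimated at 450 nM, with an expected range of 170 nM to 1100 nM.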

Compound 3, half-maximal inhibitory concentration: 420 nM
Compound 3: the middle estimate sits 1.1-fold (0.03 log units) above what was measured; the measured number falls inside the stated range.
By their numbers in this assay, from the lowest: compound 1; then compounds 2 and 3 (each within the scatter of the next).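

Among these compounds, the second methyl on the amine nitrogen gives a 2.0-fold higher number from compound 2 to compound 3 (0.30 log units; within the scatter), so in this assay compound 2 and compound 3 cannot be told apart, whereas the first methyl step on this nitrogen lay beyond the scatter. Taken whole, dimethylamino in place of amino gives a 5.3-fold higher number from compound 1 to compound 3 (0.72 log units; beyond the scatter) and is the clearest separation in the set, leaving compound 1 alone with the lowest number and its steps to both methylated compounds beyond the scatter. Nothing on hand bears on the reason for these numbers.

Open, as far as these compounds go, is whether an ethyl group on the amine nitrogen, or pyrrolidine in place of dimethylamino, would stay level with compound 3 or move away from it. Also open, from the compounds shown here alone, is how a longer chain carrying the amino group, or an acetyl group on its nitrogen, would read against compound 1.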